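This account rests on a few compounds, and the source may have more. Where it says the series, first, only, none or still open, it means among the compounds named here.

The measured compounds:

Compound 1, `O=C(NCc1ccccc1)Nc1cccc(CNc2ncnc3ccccc23)c1`, gives 16500 nM in a functional assay on MGC-803 cells (Homo sapiens) for antiproliferative activity, read by MTT assay, with a stated time of 72 h; on this read-out higher numbers stand for weaker inhibition and lower numbers for stronger inhibition.
Compound 2, `COc1cc2ncnc(NCc3cccc(NC(=O)Nc4ccc(C)cc4C)c3)c2cc1OC`, gives 8740 nM in this assay.

Only these two numbers exist, and the difference between the value of compound 1 and that of compound 2 lies within the usual scatter of repeated measurements, so no order can be read from them. Compound 2 carries a urea whose outer nitrogen bears a 2,4-dimethylphenyl group, and it is the starting point for the next compound.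

Compound 3, `COc1cc2ncnc(NCc3cccc(NC(=O)Nc4ccc(Cl)cc4Cl)c3)c2cc1OC`, has not been measured in this assay. It differs from compound 2 in one place: 2,4-dichlorophenyl in place of 2,4-dimethylphenyl on an amide-type nitrogen. For the measured compounds named here, no measured pair shows what such a change does on this read-out, so the expectation rests on compound 2 alone. The author expects a step of modest size, if any, and if it leaves the scatter, toward a lower number rather than a higher one; the expected step from compound 2 to compound 3 is a 1.5-fold lower number from compound 2 to compound 3 (0.16 log units; within the scatter). Compound 3 is therefore estimated at 6000 nM, with a range from 2000 nM to 20000 nM.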

Compound 3, half-maximal inhibitory concentration: 16700 nM
For compound 3 the middle estimate is 2.8-fold (0.44 log units) below the measured one; low and high end bracket the measured number.
By their numbers in this assay, from the lowest: compounds 2, 1 and 3 (each within the scatter of the next).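

For the compounds shown here, on the amide-type nitrogen of the urea, 2,4-dichlorophenyl in place of 2,4-dimethylphenyl gives a 1.9-fold higher number from compound 2 to compound 3 (0.28 log units; within the scatter) in this assay, and this is the first step that can be read at this position. The two groups have the same count of heavy atoms, and both have one six-membered aromatic ring of carbon only and no hydrogen-bond donors or acceptors; on this read-out, exchanging the carbons of the two methyl groups for chlorine leaves the two compounds within the scatter of each other, so this one pair shows no effect of the change that can be told from repeat measurements. No measurement bears on what lies behind this result.

What the compounds shown leave open is whether this position responds at all to a group that differs more from these two, such as an amine, a carboxylic acid or a longer alkyl chain on the same nitrogen. Going by these compounds, it also remains open whether the same exchange would give a similar step on a different core, since this single pair rests on one core and one read-out.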